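A Phenyl Side Chain on the Amino Ester

A few compounds are considered here, and "the series" means these few. Any claim that something is new, unique, unknown or untested is made for them only; others in the source may bear on it.

Compound 2 `CC(C)[C@H](N)C(=O)OCC(C)(C)COC1(c2ccc(Cl)cc2)c2ccccc2C(=O)N1Cc1ccc(Cl)cc1` carries an amino ester on a branched chain attached to the shared core. In a functional assay on HCT-116 cells (Homo sapiens) for inhibition, read by fluorescence, with a stated time of 48 h (a lower number here means a stronger inhibitor of growth, a higher number a weaker inhibitor of growth), compound 2 gives 40000 nM, the lowest of the three numbers recorded, though the gaps are small: compound 1 `CC(C)[C@H](N)C(=O)OCCCOC1(c2ccc(Cl)cc2)c2ccccc2C(=O)N1Cc1ccc(Cl)cc1` gives 60000 nM and compound 3 `CC(C)[C@H](N)C(=O)OCC(C)(C)COC1(c2ccc(Cl)cc2)c2ccccc2C(=O)N1Cc1ccccc1` gives 65000 nM, and the steps of a 1.5-fold lower number from compound 1 to compound 2 (0.18 log units; within the scatter) and a 1.6-fold higher number from compound 2 to compound 3 (0.21 log units; within the scatter) both sit within the scatter. Compound 4 `CC(C)(COC(=O)[C@@H](N)c1ccccc1)COC1(c2ccc(Cl)cc2)c2ccccc2C(=O)N1Cc1ccc(Cl)cc1` differs from compound 2 by phenyl in place of isopropyl on a saturated chain carbon bound to an amine nitrogen and a carbonyl carbon. Among the compounds with values here, no measured step touches this part of the molecule, so the change itself is untested; the two recorded steps show only that edits elsewhere moved nothing beyond the scatter. Compound 4 is therefore expected to stay close, a step of no change at the digits printed from compound 2 to compound 4 (within the scatter), with an estimated 40000 nM and a range from 15000 nM to 110000 nM.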

Compound 4, concentration for 50% growth inhibition: 38000 nM
Estimate against measurement, compound 4: 1.1-fold (0.02 log units) above; low and high end bracket the measured number.
By their numbers in this assay, from the lowest: compounds 4, 2, 1 and 3 (each within the scatter of the next).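

Swapping isopropyl for phenyl on the saturated chain carbon bound to an amine nitrogen and a carbonyl carbon gives a 1.1-fold lower number from compound 2 to compound 4 (0.02 log units; within the scatter) in this assay. Within the data shown here, this is the first measured change at this position, and it shows that a six-membered aromatic ring of carbon only can stand there with no shift beyond the scatter. No evidence is available to explain this result. Going by these compounds, what remains open is whether a different group here, such as cyclohexyl or a carboxylic acid, would move the number beyond the scatter.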